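Series notes: piperidin-1-yl to 4-carbamoylpiperidin-1-yl

A few compounds are considered here, and "the series" means these few. Any claim that something is new, unique, unknown or untested is made for them only; others in the source may bear on it.

In an ADME assay on HEK-293T cells (Homo sapiens) for cytotoxicity, read by luminescence, with a stated time of 24 h (a higher number here means that more compound is tolerated, a lower number that less compound is tolerated), compound 1 `CCOC(=O)c1cc2sccc2n1Cc1ccc(OC)cc1` gives > 100000 nM as a limit and not a number. Compound 2 `COc1ccc(Cn2c(C(=O)N3CCCC3)cc3sccc32)cc1` gives > 100000 nM as a limit too. Compound 3 `COc1ccc(Cn2c(C(=O)N3CCCCC3)cc3sccc32)cc1` gives > 100000 nM as a limit as well, so its standing is known only as a limit. The measured set shows only the limit of > 100000 nM in this assay, at which 3 of the 3 values shown sit, and no number.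

Compound 4 `COc1ccc(Cn2c(C(=O)N3CCC(C(N)=O)CC3)cc3sccc32)cc1` differs from compound 3 by carbamoyl in place of hydrogen on a saturated ring carbon in the change of piperidin-1-yl to 4-carbamoylpiperidin-1-yl. Among the compounds with values here, no measured compound carries carbamoyl. The nearest measured changes, all on a carbonyl carbon, are a step that the two limits leave unreadable from compound 2 to compound 3 and a step that the two limits leave unreadable from compound 1 to compound 3 along with a step that the two limits leave unreadable from compound 1 to compound 2 and none gives a size to carry over.

No step beyond the scatter and no direction is therefore expected in this assay and the estimated step is a number no higher from compound 3 to compound 4 (the limit leaves the size open) for now. Compound 4 is estimated at 100000 nM with an expected range from 50000 nM to 200000 nM and will most likely be reported only as a limit.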

Compound 4, half-maximal cytotoxic concentration: > 100000 nM
Compound 4 was reported as a limit (the forecaster's own chance of this, stated with the estimate: 85%); the middle value sits exactly at the limit.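

In this assay compound 4 gives > 100000 nM, a limit and not a number, and the steps to it from compound 1, compound 2 and compound 3 cannot be read. The compounds shown leave open at what concentration any of them reaches half-maximal cytotoxicity, and whether carbamoyl in place of hydrogen shifts that concentration.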